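The source may hold more compounds than are shown below. What is called first, only, known or untested is meant among the compounds shown, and "the series" means these compounds.

Measured in a functional assay on HCT-116 cells (Homo sapiens) for inhibition, read by MTT assay, with a stated time of 48 h; on this read-out lower numbers stand for stronger inhibition and higher numbers for weaker inhibition:
- Compound 1 `COc1ccc(CN(C(=O)C(C)Br)c2cc(OC)c(OC)c(OC)c2)cc1O`: 140 nM
- Compound 2 `COc1ccc(CN(C(=O)C=C(C)C)c2cc(OC)c(OC)c(OC)c2)cc1O`: 290 nM

Of these two, compound 2 gives the higher number, 290 nM, and so the weaker inhibition. For the measured compounds named here, its only neighbour on this scale is compound 1, at 140 nM.

Compound 3 `C/C=C/C=C/C(=O)N(Cc1ccc(OC)c(O)c1)c1cc(OC)c(OC)c(OC)c1` has not yet been measured. It keeps the shared core of compound 2 and alters only the group on the carbonyl carbon: penta-1,3-dien-1-yl in place of 2-methylprop-1-en-1-yl on a carbonyl carbon. In words, this places penta-1,3-dien-1-yl in place of 2-methylprop-1-en-1-yl on a carbonyl carbon.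

Going by the values given here, no measured pair makes this exact swap. Among the compounds with values here, the one measured change at this carbonyl carbon is a 2.1-fold higher number from compound 1 to compound 2 (0.32 log units; beyond the scatter), a modest step in which 2-methylprop-1-en-1-yl replaced 1-bromoethyl. With a single step as a guide, no firm direction can be read for compound 3, and a move of similar or smaller size is expected in this assay, quite possibly none beyond the scatter. The expected change is a 1.2-fold lower number from compound 2 to compound 3 (0.06 log units; within the scatter). Compound 3 is estimated at 250 nM, with an expected range of 80 nM to 800 nM.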

Compound 3, half-maximal inhibitory concentration: 180 nM
Compound 3: middle estimate off by 1.4-fold (0.14 log units), on the high side, within the range that was stated.
By their numbers in this assay, from the lowest: compounds 1, 3 and 2 (each within the scatter of the next, the first and the last beyond it).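

In this assay, putting penta-1,3-dien-1-yl on the carbonyl carbon in place of 2-methylprop-1-en-1-yl gives a 1.6-fold lower number from compound 2 to compound 3 (0.21 log units; within the scatter) and so shows that this position accepts a chain of 5 carbon with 2 double bonds without a change that can be told from the noise of repeat measurements. Set against the bromine-bearing group, the same chain gives a 1.3-fold higher number from compound 1 to compound 3 (0.11 log units; within the scatter) as its result, so compound 3 cannot be separated from either neighbour, even though the other pair in the set does separate, with a 2.1-fold higher number from compound 1 to compound 2 (0.32 log units; beyond the scatter) as its step. No measurement is available that would explain these numbers.

A saturated pentyl chain at the same carbonyl carbon would show whether the 2 double bonds of penta-1,3-dien-1-yl matter at all for the number read in this assay or whether chain size alone is enough. The compounds shown also leave open how this position responds to a group of a different kind, such as an amine or a carboxylic acid, as all three groups here are small and built from carbon, apart from the single bromine.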